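A changed amine group: compound 3 to compound 4

A few compounds are considered here, and "the series" means these few. Any claim that something is new, unique, unknown or untested is made for them only; others in the source may bear on it.

Measured in a physicochemical assay for solubility, in phosphate buffer, measured as thermodynamic solubility, at pH 2; on this read-out lower numbers stand for lower solubility and higher numbers for higher solubility:
- Compound 1 `NC1CCN(c2nc3c(c(Nc4ccc(C(F)(F)F)cc4)n2)CCN(c2ncccc2C(F)(F)F)CC3)C1`: > 215 ug/mL, a limit
- Compound 2 `CCC(CC)N1CCN(c2nc3c(c(Nc4ccc(C(F)(F)F)cc4)n2)CCN(c2ncccc2C(F)(F)F)CC3)CC1`: 243 ug/mL
- Compound 3 `CN1CCCCC1CNc1nc2c(c(Nc3ccc(C(F)(F)F)cc3)n1)CCN(c1ncccc1C(F)(F)F)CC2`: > 277 ug/mL, a limit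

In this assay, compound 3 gives only a limit, > 277 ug/mL. Compound 4 `CNC1CCN(c2nc3c(c(Nc4ccc(C(F)(F)F)cc4)n2)CCN(c2ncccc2C(F)(F)F)CC3)C1` differs from it as follows: 3-(methylamino)pyrrolidin-1-yl in place of ((1-methylpiperidin-2-yl)methyl)amino on an aromatic carbon. In words, 3-(methylamino)pyrrolidin-1-yl stands in place of ((1-methylpiperidin-2-yl)methyl)amino on an aromatic carbon. The nearest measured change is a step that the two limits leave unreadable from compound 1 to compound 3, so it offers no size to carry over. The other measured change is an at least 1.1-fold higher number from compound 2 to compound 3 (0.05 log units; that floor lies within the scatter). Neither shows a step beyond the scatter, so none is expected here. The expected step is an at least 1.0-fold lower number from compound 3 to compound 4 (0.01 log units; that floor lies within the scatter). The estimate for compound 4 is 270 ug/mL, with an expected range of 150 ug/mL to 450 ug/mL.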

Compound 4, solubility: > 220 ug/mL
Compound 4: no number, only a limit; the forecaster's own chance of this, stated with the estimate: 55%; the middle value does not contradict the limit.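

In this assay, within the data shown here, compound 4 gives only a limit, > 220 ug/mL, so no step from compound 1, compound 2 or compound 3 to compound 4 can be read. The compounds shown leave open whether methyl in place of hydrogen on an amine nitrogen, which separates compound 1 from compound 4, changes the read-out at all.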